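The compounds below may be only part of what the source reports. "The series", "measured", "known", "first", "only" and "open" are said of these compounds alone.

Measured so far:
- Compound 1 `O=C(CCCCC1CCSS1)Nc1ccccn1`: 0.89%
- Compound 2 `O=C(CCCCC1CCSS1)Nc1ccc(Cl)cn1`: "not active" (no number reported)
- Compound 3 `O=C(CCCCC(S)CCS)Nc1ccccn1`: "not active" (no number reported)

In a functional assay on Bel-7402 cells (Homo sapiens) for inhibition, read by MTT assay, with a stated time of 24 h, tested at 0.1 ug/mL (on this read-out higher numbers stand for more inhibition of growth at the one concentration tested and lower numbers for less inhibition of growth), only compound 1 gives a number, 0.89%. Compound 3 has no single number and stands with the entry "not active" (no number reported), a result it shares with compound 2.

Compound 4 `O=C(CCCCC(S)CCS)Nc1ccc(Cl)cn1` has not yet been measured. The change chloro in place of hydrogen on an aromatic carbon puts chloro in place of hydrogen on an aromatic carbon.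

Among the measured compounds shown here, no measured step shows directly what this change does here. Compound 3 reads "not active" (no number reported), and compound 2, which also carries the chloro, reads "not active" (no number reported), so no step beyond the usual scatter is expected in this assay. Compound 4 is expected to give about 1%, with an estimated range of 0% to 8%.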

Compound 4, percent growth inhibition at one concentration: "not active" (no number reported)
Compound 4 has no reported number here, and the estimate cannot be compared.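

Compound 3 and compound 4 both read "not active" without a number, so no step can be read for chloro in place of hydrogen. No measurement shown accounts for this result. From the compounds shown here alone, whether chloro changes growth inhibition at all stays open.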